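Trading a Methylsulfonyl for a Methyl on the Core

The source may hold more compounds than are shown below. What is called first, only, known or untested is meant among the compounds shown, and "the series" means these compounds.

For the measured compounds named here, compound 2 `CS(=O)(=O)c1coc(C(=O)CCCCCCc2ccccc2)n1` is the only compound here with a definite number: in an assay on HEK-293T cells for inhibition of diacylglycerol lipase-alpha (Homo sapiens), read by colorimetric assay (a lower number here means a stronger inhibitor, a higher number a weaker inhibitor), compound 2 gives 389 nM. Compound 1 `O=C(CCCCCCc1ccccc1)c1nnn(-c2cccs2)n1` has a different core, and in this assay compound 1 gives > 10000 nM, which is a limit of the assay rather than a number. Compound 3 `Cc1coc(C(=O)CCCCCCc2ccccc2)n1` differs from compound 2 in one place: methyl in place of methylsulfonyl on an aromatic carbon. Going by the values given here, no measured pair shows this exact change, so the size of the step is only an expectation. Compound 3 is expected to be weaker, with the step of a 5.1-fold higher number from compound 2 to compound 3 (0.71 log units; beyond the scatter) going beyond the usual scatter. In this assay compound 3 is therefore estimated at 2000 nM, likely between 600 nM and 8000 nM.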

Compound 3, half-maximal inhibitory concentration: > 10000 nM
Compound 3: no number, only a limit; the forecaster's own chance of this, stated with the estimate: 20%; middle value at least 5.0-fold (0.69 log units) away from the limit.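

Replacing methylsulfonyl with methyl on this aromatic carbon gives an at least 25-fold higher number from compound 2 to compound 3 (1.41 log units; beyond the scatter), so in this assay the activity of this series depends strongly on what this position carries. Compound 3 gives only a limit of the assay, so the step is a minimum and its true size stays unknown: the limit of > 10000 nM in this assay, at which 2 of the 3 values shown sit.

A single pair cannot show which feature of methylsulfonyl matters. On these data alone, it remains open whether a nitrile, a carboxylic acid or an amine on this carbon would keep the number close to that of compound 2.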